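This account rests on a few compounds, and the source may have more. Where it says the series, first, only, none or still open, it means among the compounds named here.

Compound 1 `Cc1ccc2c(O)c(Cc3ccccc3)cnc2n1` carries a hydroxy group on its core, and in an assay for binding affinity to adenosine receptor A1 (Homo sapiens) (on this read-out lower numbers stand for stronger inhibition and higher numbers for weaker inhibition), compound 1 gives 4180 nM. Compound 2 `Cc1ccc2c(N=[N+]=[N-])c(Cc3ccccc3)cnc2n1` bears an azido group in place of that hydroxy. In this assay compound 2 reaches only a limit of the assay, > 10000 nM. The step of an at least 2.3-fold higher number from compound 1 to compound 2 (0.37 log units; beyond the scatter) rests on (the limit of > 10000 nM in this assay, at which 1 of the 2 values shown sits), so on the numbers shown compound 2 stands at the weak end of the pair. Compound 3 `Cc1ccc2c(NN)c(Cc3ccccc3)cnc2n1` differs from compound 2 by aminoamino in place of azido on an aromatic carbon. Going by the values given here, the single measured step, from compound 1 to compound 2, ran toward weaker binding when azido replaced hydroxy; no measured step involves the aminoamino group itself, so its effect is unknown. A step of an at least 1.2-fold lower number from compound 2 to compound 3 (0.09 log units; that floor lies within the scatter) toward somewhat stronger binding is expected for compound 3, though its size is uncertain and may not exceed the scatter. For compound 3 the estimate in this assay is 8000 nM, within 2500 nM to 25000 nM.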

Compound 3, inhibition constant: > 10000 nM
Compound 3: no number, only a limit; the forecaster's own chance of this, stated with the estimate: 40%; at least 1.2-fold (0.09 log units) between middle value and limit.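

In this assay compound 3 gives > 10000 nM, which is a limit of the assay. Aminoamino in place of hydroxy gives an at least 2.3-fold higher number from compound 1 to compound 3 (0.37 log units; beyond the scatter), so azido and aminoamino, two different groups on this aromatic carbon opposite the ring nitrogen, both leave the number higher than the hydroxy group of compound 1 does. Azido has no hydrogen-bond donors and aminoamino has some, yet no gain or loss from that exchange can be read, because both compounds stop at the same limit: the limit of > 10000 nM in this assay, at which 2 of the 3 values shown sit.

As far as these compounds go, how far compound 2 and compound 3 lie beyond that limit, and how they rank against each other, stays open. Also open, from the compounds shown here alone, is whether an amine, a methoxy group or a carboxylic acid on this carbon would match the hydroxy group of compound 1 or improve on it.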